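The compounds below may be only part of what the source reports. "The series", "measured", "known", "first", "only" and "open" are said of these compounds alone.

Measured in an ADME assay on Vero cells (Chlorocebus sabaeus) for antiproliferative activity, read by MTT assay, with a stated time of 72 h; on this read-out lower numbers stand for stronger inhibition and higher numbers for weaker inhibition:
compound 1 `COc1cccc(N(C)S(=O)(=O)C2CC3OC2C(c2ccc(NC(=O)CCCCCCC(=O)O)cc2)=C3c2ccc(O)cc2)c1` gives > 100000 nM
compound 2 `CCN(c1cccc(C)c1)S(=O)(=O)C1CC2OC1C(c1ccc(NC(=O)CCCCCCC(=O)O)cc1)=C2c1ccc(O)cc1` gives > 100000 nM

Compound 1 stands only at a limit (> 100000 nM) and has no number to start from. Compound 2 also gives only a limit (> 100000 nM) and no number. Together the two show the limit of > 100000 nM in this assay, at which 2 of the 2 values shown sit, and nothing finer.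

Next comes compound 3 `CCN(c1ccc(OC)cc1)S(=O)(=O)C1CC2OC1C(c1ccc(NC(=O)CCCCCCC(=O)O)cc1)=C2c1ccc(O)cc1` with this change: ethyl(4-methoxyphenyl)amino in place of (3-methoxyphenyl)(methyl)amino on a sulfonyl sulfur and in words, ethyl(4-methoxyphenyl)amino in place of (3-methoxyphenyl)(methyl)amino on a sulfonyl sulfur. Among the compounds with values here, the one measured step that bears on it is a step that the two limits leave unreadable from compound 1 to compound 2 and it falls at the same place. Its size cannot be read.

Compound 2 stays at a limit (> 100000 nM) after its change at that place, so no movement is expected here. The estimated move is a number no higher from compound 1 to compound 3 (the limit leaves the size open) in this assay with no direction favoured and nothing expected beyond the scatter. For compound 3 the estimated value is 100000 nM with an expected range from 50000 nM to 200000 nM and a report of only a limit is the likeliest outcome.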

Compound 3, half-maximal inhibitory concentration: > 100000 nM
Compound 3: no number, only a limit (the forecaster's own chance of this, stated with the estimate: 85%); the middle value sits exactly at the limit.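

In this assay compound 3 gives > 100000 nM, which is a limit and not a number. No new step can be read among compound 1, compound 2 and compound 3: the limit of > 100000 nM in this assay, at which 3 of the 3 values shown sit. The compounds shown leave open whether any of these groups on the sulfonamide nitrogen changes the half-maximal inhibitory concentration, and by how much.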